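Removing a methyl from the thiazole of compound 3

This account rests on a few compounds, and the source may have more. Where it says the series, first, only, none or still open, it means among the compounds named here.

Measured compounds:
compound 1, `O=C(Cn1cc(-c2ccc(F)cc2)nn1)Nc1nccs1`, 190 nM
compound 2, `O=C(Cn1cc(-c2ccccc2Cl)nn1)Nc1nccs1`, 60 nM
compound 3, `Cc1csc(NC(=O)Cn2cc(-c3cccs3)nn2)n1`, 40 nM

All three were tested in a functional assay on BMDM cells (Mus musculus, strain C57BL/6) for inhibition, with a stated time of 2 days; a lower number here means a stronger inhibitor, a higher number a weaker inhibitor. Among them compound 3 has the lowest number; its nearest neighbour is compound 2, which lies within the scatter of it, while compound 1 stands furthest away, beyond the scatter. The gap between compound 3 and compound 2 is within the scatter. Among the measured compounds shown here, compound 3 therefore cannot be called the most potent of the set, only the one with the lowest number.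

The next compound is compound 4, `O=C(Cn1cc(-c2cccs2)nn1)Nc1nccs1`. It differs from compound 3 in one place: hydrogen in place of methyl on an aromatic carbon The remainder of the molecule, including the thiophene and the shared core, is unchanged.

For the measured compounds named here, only one measured step exists, a 3.2-fold lower number from compound 1 to compound 2 (0.50 log units; beyond the scatter), and it concerns the aryl group on the triazole, not the thiazole. Going by the values given here, no measured pair speaks to the methyl on the 1,3-thiazol-2-yl group. Among the compounds with values here, with no step bearing on this change, the expectation is that the number for compound 4 stays close to that of compound 3, with no step beyond the scatter; the expected step is a 1.3-fold higher number from compound 3 to compound 4 (0.10 log units; within the scatter). Compound 4 is therefore estimated at 50 nM, in the range 22 nM to 110 nM.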

Compound 4, half-maximal inhibitory concentration: > 30000 nM
Compound 4 gave a limit, no number; the forecaster's own chance of this, stated with the estimate: 2%; at least 600-fold (2.77 log units) between middle value and limit.
By their numbers in this assay, from the lowest: compounds 3 and 2 (each within the scatter of the next); then compound 1. At a limit, above all of these: compound 4.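

In this assay compound 4 gives a limit of the assay and not a number: the limit of > 30000 nM in this assay, at which 1 of the 4 values shown sits.

Among the compounds shown here, on the thiophen-2-yl series, the methyl on the aromatic carbon next to the ring nitrogen, a place no earlier pair touched, turns out to matter a great deal: the change from 4-methyl-1,3-thiazol-2-yl to 1,3-thiazol-2-yl gives an at least 750-fold higher number from compound 3 to compound 4 (2.87 log units; beyond the scatter), a large step set against the modest 3.2-fold lower number from compound 1 to compound 2 (0.50 log units; beyond the scatter) among the earlier compounds. Lacking the methyl does not alone decide the outcome, however, since the plain 1,3-thiazol-2-yl also stands in the two compounds with a phenyl group, and the thiophen-2-yl change on that plain ring gives an at least 500-fold higher number from compound 2 to compound 4 (2.69 log units; beyond the scatter) and an at least 150-fold higher number from compound 1 to compound 4 (2.19 log units; beyond the scatter).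

The compounds shown leave open whether the methyl counts for as much when a 2-chlorophenyl or 4-fluorophenyl group sits on the other end of the molecule, so the link between the two places rests on these few compounds alone. They also leave open whether an ethyl, a chlorine or a methoxy on the same ring carbon would keep the number of compound 3 in this assay.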